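Swapping Methyl for Fluoro on a Benzyl Group

The compounds below may be only part of what the source reports. "The series", "measured", "known", "first", "only" and "open" are said of these compounds alone.

Measured compounds:
compound 1, `Cc1ccc(CN2C(=O)N(Cc3ccccc3)S(=O)(=O)n3cccc32)cc1`, 241000 nM
compound 2, `O=C1N(Cc2ccccc2Cl)c2cscc2S(=O)(=O)N1Cc1ccccc1`, > 119000 nM

Of the compounds shown here, two have been tested in an ADME assay on MT4 cells (Homo sapiens) for cytotoxicity, read by MTT assay, with a stated time of 5 days; a higher number here means that more compound is tolerated, a lower number that less compound is tolerated. For the measured compounds named here, compound 1 gives 241000 nM in this assay, the only plain number in the set. For compound 2 the result is > 119000 nM, which is a limit of this assay rather than a number. So compound 1 stands as the one compound with a measured value, next to the limit of > 119000 nM in this assay, at which 1 of the 2 values shown sits, for the other. Compound 2 has a different core, so nothing is read from compound 2 about the change that follows.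

Compound 3, `O=C1N(Cc2ccc(F)cc2)c2cccn2S(=O)(=O)N1Cc1ccccc1`, has not yet been tested. It differs from compound 1 in one place: fluoro in place of methyl on an aromatic carbon. This is the smallest kind of edit, one heavy atom for one heavy atom, with no ring and no donor or acceptor gained or lost.

Going by the values given here, with no measured pair of this kind to lean on, the step expected in this assay from compound 1 to compound 3 is none beyond the scatter, that is a 1.1-fold lower number from compound 1 to compound 3 (0.04 log units; within the scatter). Compound 3 is therefore estimated to give about 220000 nM, within a range from 100000 nM to 450000 nM.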

Compound 3, half-maximal cytotoxic concentration: 150000 nM
Compound 3: middle estimate off by 1.5-fold (0.17 log units), on the high side; the range from low to high includes it.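

The swap of 4-methylbenzyl to 4-fluorobenzyl now has a measured result in this assay, which gives a 1.6-fold lower number from compound 1 to compound 3 (0.21 log units; within the scatter). For the compounds shown here, the earlier compounds held no pair that differs in one place, so this is the first direct reading of the change, and it shows that methyl and fluoro on this aromatic carbon cannot be told apart in this read-out, even though the two printed numbers differ. For compound 2 the result is a limit and not a number, and its core is different, so it adds no reading of this swap: the limit of > 119000 nM in this assay, at which 1 of the 3 values shown sits.

From the compounds shown here alone, what remains open is whether a larger or very different group on the same aromatic carbon, such as an amine, a carboxylic acid or a longer chain, would move the number beyond the scatter, or whether it would stay as close as fluoro does to methyl. Going by these compounds, it also remains open whether the same swap of methyl for fluoro would read the same way on the other benzyl group or on the core of compound 2.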